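From naphthalen-1-yl to naphthalen-2-yl in a cell assay

The compounds below may be only part of what the source reports. "The series", "measured", "known", "first", "only" and "open" are said of these compounds alone.

- compound 1 `O=C1C=CC2(C=C1)OCC(=O)N2c1nc(-c2ccc3ccccc3c2Br)nn1-c1ccccc1` gives 100 nM
- compound 2 `O=C1C=CC2(C=C1)OCC(=O)N2c1nc(-c2cccc3ccccc23)nn1-c1ccccc1` gives 80 nM

In a functional assay on A549 cells (Homo sapiens) for antiproliferative activity, with a stated time of 5 days (on this read-out higher numbers stand for weaker inhibition and lower numbers for stronger inhibition), compound 1 gives 100 nM and compound 2 gives 80 nM so these two cannot be told apart. Compound 3 `O=C1C=CC2(C=C1)OCC(=O)N2c1nc(-c2ccc3ccccc3c2)nn1-c1ccccc1` has not yet been measured. Its change from compound 2 is naphthalen-2-yl in place of naphthalen-1-yl on an aromatic carbon on an aromatic carbon, with naphthalen-2-yl in place of naphthalen-1-yl. Within the data shown here, the only measured step that bears on this is a 1.3-fold lower number from compound 1 to compound 2 (0.10 log units; within the scatter) and it offers no sign of a large effect from swapping these groups. The expected step is a 1.3-fold higher number from compound 2 to compound 3 (0.10 log units; within the scatter) and so no change beyond the scatter is expected. For compound 3 the estimate is 100 nM (expected range 40 nM to 250 nM).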

Compound 3, half-maximal inhibitory concentration: 140 nM
Compound 3: middle estimate off by 1.4-fold (0.15 log units), on the low side; the range from low to high includes it.
By their numbers in this assay, from the lowest: compounds 2, 1 and 3 (each within the scatter of the next).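

In this assay, shifting the attachment from naphthalen-1-yl to naphthalen-2-yl gives a 1.8-fold higher number from compound 2 to compound 3 (0.24 log units; within the scatter), so on this aromatic carbon of the five-membered ring, the two ways of joining the same two rings cannot be told apart. Hydrogen in place of bromo on the naphthalen-2-yl group gives a 1.4-fold higher number from compound 1 to compound 3 (0.15 log units; within the scatter), and this step cannot be told from the scatter either. Still open, from the compounds shown here alone, is whether a group of another kind here, such as an amine or a carboxylic acid, would move the number beyond the scatter. No available data address what lies behind these small steps.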